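The source may report more compounds than this note shows. Statements on the series, on what has been measured and on what is new or still open speak of the compounds shown alone.

Measured compounds:
compound 1 `CCc1oc2ccc(OC)cc2c1C(=O)c1cc(Br)c(O)c(Br)c1` gives 42 nM in an assay for inhibition of solute carrier family 22 member 12 (Homo sapiens), read by scintillation counting, with a stated time of 60 min; on this read-out higher numbers stand for weaker inhibition and lower numbers for stronger inhibition;
compound 2 `CCc1oc2ccc(O)cc2c1C(=O)c1cc(Br)c(O)c(Br)c1` gives 189 nM;
compound 3 `CCc1cc2c(C(=O)c3cc(Br)c(O)c(Br)c3)c(OC)ccc2o1` gives 358 nM.

Compound 1 and compound 3 share the same atoms joined differently; the difference between the two cores is not broken down here. On the core of compound 1, the change hydrogen in place of methyl on an oxygen on an aromatic ring produced a 4.5-fold higher number from compound 1 to compound 2 (0.65 log units; beyond the scatter). Compound 4 `CCc1cc2c(C(=O)c3cc(Br)c(O)c(Br)c3)c(O)ccc2o1` carries the same change on the core of compound 3, (hydrogen in place of methyl on an oxygen on an aromatic ring), and it is unmeasured. Among the compounds with values here, the step from compound 3 to compound 4 is expected to be of comparable size to the earlier one, estimated as a 4.5-fold higher number from compound 3 to compound 4 (0.65 log units; beyond the scatter), because that rests on the single matched step a 4.5-fold higher number from compound 1 to compound 2 (0.65 log units; beyond the scatter) seen on the other core. Compound 4 is therefore estimated at 1600 nM, with an expected range from 500 nM to 5000 nM.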

Compound 4, half-maximal inhibitory concentration: 83 nM
Compound 4: the middle estimate sits 19-fold (1.29 log units) above what was measured; the measured number lies below the stated range.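

Replacing methoxy by hydroxy gives a 4.3-fold lower number from compound 3 to compound 4 (0.63 log units; beyond the scatter) in this assay, opposite in direction to a 4.5-fold higher number from compound 1 to compound 2 (0.65 log units; beyond the scatter), so in this series the direction of the step depends on the core. The two steps do not agree: the same change on two cores in this assay, a 4.5-fold higher number (0.65 log units; beyond the scatter) from compound 1 to compound 2 and a 4.3-fold lower number (0.63 log units; beyond the scatter) from compound 3 to compound 4, 19-fold (1.29 log units) apart, beyond the scatter of two such steps. Within the data shown here, this rests on a single matched pair per core and shows only that a step measured on one core cannot be carried over to the other; it does not show what in the cores sets the direction, or whether other changes behave the same way.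

From the compounds shown here alone, whether the two cores also part ways with a longer chain on that oxygen, such as ethoxy, remains open. The same holds for an amine in place of the oxygen group.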